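The compounds below may be only part of what the source reports. "The series", "measured", "known", "first", "only" and "open" are said of these compounds alone.

Measured in a functional assay on cells (Homo sapiens) for antiproliferative activity, read by WST assay, with a stated time of 3 days; a lower number here means a stronger inhibitor, a higher number a weaker inhibitor:
- compound 1 `O=c1cc(I)n([C@@H]2O[C@H](CO)[C@@H](O)[C@H]2O)c(=O)[nH]1`: 27800 nM
- compound 2 `CNc1cc(=O)[nH]c(=O)n1[C@@H]1O[C@H](CO)[C@@H](O)[C@H]1O`: > 50000 nM (a limit, not a number)

Compound 2 stands at the limit of > 50000 nM in this assay, at which 1 of the 2 values shown sits. Its value is a limit of the assay, so it gives no exact position.

Compound 3 `CN(C)c1cc(=O)[nH]c(=O)n1[C@@H]1O[C@H](CO)[C@@H](O)[C@H]1O` follows from compound 2 by methyl in place of hydrogen on a nitrogen on an aromatic ring, or methylamino to dimethylamino.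

Within the data shown here, no measured step makes this change. The nearest is an at least 1.7-fold higher number from compound 1 to compound 2 (0.25 log units; that floor lies within the scatter), which is methylamino in place of iodo on an aromatic carbon. It bears on the same place only indirectly, and its size is only a floor. No step beyond the scatter is therefore expected in this assay, and a reading at the same limit is likely. The estimated step is a number no higher from compound 2 to compound 3 (the limit leaves the size open).

For compound 3 the expected value is 50000 nM, with an estimated range of 25000 nM to 80000 nM.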

Compound 3, half-maximal inhibitory concentration: > 50000 nM
Compound 3: a limit, no number; the forecaster's own chance of this, stated with the estimate: 75%; the middle value lies on the limit itself.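

Compound 3 gives > 50000 nM in this assay, and this value is a limit of the assay, not a number. The step from compound 2 to compound 3 cannot be read, so adding a methyl on this nitrogen gives no measurable change, only a second reading at the limit. Dimethylamino in place of iodo on an aromatic carbon gives an at least 1.7-fold higher number from compound 1 to compound 3 (0.25 log units; that floor lies within the scatter), so neither amino group can yet be told apart from iodo, and the limit now holds most of the series: the limit of > 50000 nM in this assay, at which 2 of the 3 values shown sit.

Going by these compounds, it remains open whether chloro, a free amine or ethylamino on this aromatic carbon would read differently from compound 1 at 27800 nM. On these data alone, the true distance between compound 2 and compound 3 also remains open.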